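Two Substituted Benzyl Ureas and a Third Untested One

The compounds below may be only part of what the source reports. "The series", "measured", "known", "first", "only" and "open" are said of these compounds alone.

Compound 2 `Cc1cc2c(-c3ccccc3)c(NC(=O)N(C)Cc3ccccc3Cl)n(C)c(=O)c2cc1C` is the stronger of the two compounds measured in an assay on IM-9 cells for binding affinity to Substance-P receptor (Homo sapiens) (on this read-out higher numbers stand for weaker inhibition and lower numbers for stronger inhibition), where compound 2 gives 4.2 nM. Among the measured compounds shown here, its only neighbour is compound 1 `Cc1cc2c(-c3ccccc3)c(NC(=O)N(C)Cc3ccccc3)n(C)c(=O)c2cc1C`, which in this assay gives 16 nM. For the measured compounds named here, the one measured step, a 3.8-fold lower number from compound 1 to compound 2 (0.58 log units; beyond the scatter), came from placing a chloro in place of hydrogen on an aromatic carbon of the benzyl ring attached to the urea nitrogen.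

Compound 3 `Cc1cc(C)cc(CN(C)C(=O)Nc2c(-c3ccccc3)c3cc(C)c(C)cc3c(=O)n2C)c1` changes that same ring in a different way: 3,5-dimethylphenyl in place of 2-chlorophenyl on a saturated chain carbon bound to an amide-type nitrogen. Going by the values given here, no measured pair shows this particular swap. The step from compound 1 to compound 2 shows only that a substituent on this ring can improve binding; it gives no direct guide to two methyl groups in place of one chloro. Within the two measured values there is therefore no firm basis, and the expectation for compound 3 is a number near compound 2, estimated as a 1.9-fold higher number from compound 2 to compound 3 (0.28 log units; within the scatter), allowing a drift either way. Compound 3 is expected to give about 8 nM in this assay, within 2 nM to 40 nM.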

Compound 3, half-maximal inhibitory concentration: 28 nM
The estimate for compound 3 lay 3.5-fold (0.54 log units) below the measured number; the measured number falls inside the stated range.
By their numbers in this assay, from the lowest: compound 2; then compounds 1 and 3 (each within the scatter of the next).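

In this assay, this ring on the saturated chain carbon does not reward every substitution: replacing 2-chlorophenyl with 3,5-dimethylphenyl gives up the advantage that compound 2 held (a 6.7-fold higher number from compound 2 to compound 3 (0.82 log units; beyond the scatter)). Compared with the plain phenyl ring, the two methyl groups produce no difference that can be told from the scatter (a 1.8-fold higher number from compound 1 to compound 3 (0.24 log units; within the scatter)), so adding groups to this ring does not by itself improve binding, and among the three compounds only the 2-chlorophenyl ring stands apart from the others. No measurement is available that would explain this difference between the chloro and dimethyl rings.

The swap from compound 2 to compound 3 changes the kind of substituent, their number and their placement all at once, so these compounds cannot show which of those changes matters. Going by these compounds, it remains open how binding would respond to a single methyl group in the place of the chloro, or to a methoxy group, an amine or a carboxylic acid on this ring.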